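This account rests on a few compounds, and the source may have more. Where it says the series, first, only, none or still open, it means among the compounds named here.

Measured compounds:
compound 1, `CCc1cc(C(C)=O)c(O)cc1OCCCCCCC#N`, 103%
compound 2, `CC(=O)c1cc(CO)c(OCCCCCCC#N)cc1O`, 40%
compound 3, `C=CCc1cc(C(C)=O)c(O)cc1OCCCCCCC#N`, 97%

In an assay on isolated protein for inhibition of leukotriene B4 receptor 1 (Homo sapiens), tested at 10 uM (on this read-out lower numbers stand for less inhibition and higher numbers for more inhibition at the one concentration tested (going by the name of the read-out)), compound 1 gives 103%, the highest of the three numbers. The nearest of the other two is reached by a number 6 percentage points lower from compound 1 to compound 3 (within the scatter), the furthest by a number 63 percentage points lower from compound 1 to compound 2 (beyond the scatter). Compound 2 and compound 3 are separated by a number 57 percentage points higher from compound 2 to compound 3 (beyond the scatter).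

Compound 4, `CCc1cc(C(C)=O)c(O)cc1OCCCCC(C)(C)C#N`, differs from compound 1 by 1-cyano-1-methylethyl in place of 2-cyanoethyl on a saturated chain carbon, four bonds along the chain from an oxygen on an aromatic ring. Among the compounds with values here, all three measured steps concern the group on the saturated chain carbon bound to the aromatic carbon; not one of them touches the chain that carries the nitrile, so no measured step bears directly on this change. Within the data shown here, what can be said is that the shared core with an ethyl group, as in compound 1, sits at the top of the read-out, and that the only change seen to lower the number was the hydroxy of compound 2. The author therefore expects in this assay no step beyond the scatter, the estimated step being a number 8 percentage points lower from compound 1 to compound 4 (within the scatter). For compound 4 the estimated value is 95%, with a range from 70% to 105%.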

Compound 4, a percentage reported as inhibition, at one concentration (the size of the read-out at that concentration, not a potency): 79%
Compound 4: the middle estimate sits 16 percentage points above what was measured; low and high end bracket the measured number.
By their numbers in this assay, from the lowest: compound 2; then compound 4; then compounds 3 and 1 (each within the scatter of the next).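

In this assay, replacing 2-cyanoethyl with 1-cyano-1-methylethyl on a saturated chain carbon, four bonds along the chain from an oxygen on an aromatic ring, gives a number 24 percentage points lower from compound 1 to compound 4 (beyond the scatter). Within the data shown here, the earlier steps all concerned the group on the saturated chain carbon bound to an aromatic carbon, so this is the first sign that the nitrile-bearing chain also matters to this read-out, though compound 4 still gives 79%. Nothing measured here explains the drop.

The compounds shown leave open whether a longer chain, or a carboxylic acid or an amine in place of the nitrile, would keep the number of compound 1 or lower it further. The read-out, taken at one concentration, also gives no potency for compound 4.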